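From Ethylamino to Dimethylamino on a Shared Core

This account rests on a few compounds, and the source may have more. Where it says the series, first, only, none or still open, it means among the compounds named here.

Compound 1 (`CNCC(=O)Nc1cc(OC)ccc1C(=O)c1cc(OC)c(OC)c(OC)c1`) and compound 2 (`CCNCC(=O)Nc1cc(OC)ccc1C(=O)c1cc(OC)c(OC)c(OC)c1`) share one core and differ only in the amine at the end of the side chain. In a functional assay on HCT-8 cells (Homo sapiens) for antiproliferative activity, read by MTT assay, with a stated time of 48 h (on this read-out higher numbers stand for weaker inhibition and lower numbers for stronger inhibition), compound 1 gives 780 nM and compound 2 gives 1560 nM on the same read-out. These two values lie within the usual scatter of each other, so compound 2 stands level with compound 1 and the pair cannot be ranked.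

Compound 3 (`COc1ccc(C(=O)c2cc(OC)c(OC)c(OC)c2)c(NC(=O)CN(C)C)c1`) has the same atoms as compound 2 but joined differently (dimethylamino in place of ethylamino on a saturated chain carbon bound to a carbonyl carbon), so that dimethylamino replaces ethylamino on a saturated chain carbon bound to a carbonyl carbon. Among the measured compounds shown here, the only measured step at this amine (a 2.0-fold higher number from compound 1 to compound 2 (0.30 log units; within the scatter)) stayed within the scatter, and no measured compound yet carries dimethylamino. One step is thin guidance, but on this evidence no step beyond the scatter is expected in this assay for this change. The expected step (a 1.3-fold lower number from compound 2 to compound 3 (0.11 log units; within the scatter)) is correspondingly small. Compound 3 is estimated at 1200 nM with an expected range from 450 nM to 3200 nM in repeat measurements.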

Compound 3, half-maximal inhibitory concentration: 790 nM
Beside the measured number, compound 3's estimate is 1.5-fold (0.18 log units) above it; the measured number falls inside the stated range.
By their numbers in this assay, from the lowest: compounds 1, 3 and 2 (each within the scatter of the next).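

In this assay, dimethylamino in place of ethylamino on a saturated chain carbon bound to a carbonyl carbon gives a 2.0-fold lower number from compound 2 to compound 3 (0.30 log units; within the scatter), so this rearrangement of the same atoms, which takes the count of hydrogen-bond donors in the group from 1 to 0, produces no step beyond the scatter. Methyl in place of hydrogen on the amine nitrogen gives a 1.0-fold higher number from compound 1 to compound 3 (0.01 log units; within the scatter), which means that compound 1, compound 2 and compound 3 now stand level and the three amines at the end of the side chain cannot be ranked. Nothing available offers an explanation for these readings.

Among the compounds shown here, what remains open is whether any group at the end of this side chain can move the number beyond the scatter at all, since every step so far lies within it. A plain primary amine, a ring amine such as piperidine or morpholine, a longer chain such as propylamino, or a carboxylic acid in this place could each answer that question, and the compounds shown give no guide to how any of them would read.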